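Swapping bromine for propyl on the para position of compound 3

The source may hold more compounds than are shown below. What is called first, only, known or untested is meant among the compounds shown, and "the series" means these compounds.

Compound 3 `CC(C)(C)N(NC(=O)c1ccc(Br)cc1)C(=O)c1ccccc1Cl` gives the lowest number of the three measured in an assay on cells for agonist activity at ecdysone receptor (Bombyx mori), read by a luciferase reporter, with a stated time of 24 h; a higher number here means that more compound is needed for the effect, a lower number that less compound is needed: compound 3 gives 33.9 nM. Compound 1 `CC(C)(C)N(NC(=O)c1ccccc1F)C(=O)c1ccccc1Cl` stands nearest, and in this assay compound 1 gives 51.3 nM, a gap that is a 1.5-fold lower number from compound 1 to compound 3 (0.18 log units; within the scatter). Compound 2 `CC(C)(C)N(NC(=O)c1cccc(Br)c1)C(=O)c1ccccc1Cl` stands furthest, and in this assay compound 2 gives 191 nM, a gap that is a 5.6-fold lower number from compound 2 to compound 3 (0.75 log units; beyond the scatter). Compound 4 `CCCc1ccc(C(=O)NN(C(=O)c2ccccc2Cl)C(C)(C)C)cc1` differs from compound 3 by propyl in place of bromo on an aromatic carbon. Among the measured compounds shown here, none of the measured steps exchanges one group for another at the same place; they move a halogen between ring positions, with a 3.7-fold higher number from compound 1 to compound 2 (0.57 log units; beyond the scatter) the other such step. So no step here shows what propyl in place of bromo does, and compound 4 is expected to stay close to compound 3, with the change estimated as a 1.2-fold higher number from compound 3 to compound 4 (0.07 log units; within the scatter). Compound 4 is therefore estimated at 40 nM in this assay, within a range from 12 nM to 130 nM.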

Compound 4, half-maximal effective concentration: 9.12 nM
The estimate for compound 4 lay 4.4-fold (0.64 log units) above the measured number; the whole stated range lies above it.
By their numbers in this assay, from the lowest: compound 4; then compounds 3 and 1 (each within the scatter of the next); then compound 2.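

In this assay, among the compounds shown here, propyl in place of bromo on an aromatic carbon para to a large group gives a 3.7-fold lower number from compound 3 to compound 4 (0.57 log units; beyond the scatter), the only step here that exchanges one group for another at the same place. The earlier compounds shown here moved a halogen between ring positions, whereas this step shows that the position takes an all-carbon chain of 3 heavy atoms in place of a single bromine, with a number that falls beyond the scatter. Nothing available accounts for this fall.

The compounds shown leave open whether a shorter chain such as ethyl or a longer one such as butyl would lower the number further or raise it again. They also do not tell how an amine or a carboxylic acid at this position would behave.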